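The source may hold more compounds than are shown below. What is called first, only, known or untested is meant among the compounds shown, and "the series" means these compounds.

In an ADME assay on HepG2 cells (Homo sapiens) for cytotoxicity, read by luminescence, CellTiter-Glo and ATP content, with a stated time of 72 h (a higher number here means that more compound is needed for the effect, a lower number that less compound is needed), two compounds that differ in one place have been measured. Compound 1 `COc1cccc(CNCCCNc2ccnc3cc(Cc4cc(C)cc(C)c4)ccc23)c1O` gives 2680 nM, and compound 2 `COc1ccc(Oc2ccc3c(NCCCNCc4cccc(OC)c4O)ccnc3c2)cc1` gives 5500 nM, the higher of the two numbers. The next compound, compound 3 `COc1cccc(CNCCCNc2ccnc3cc(Cc4ccc(C#N)cc4)ccc23)c1O`, keeps the shared core and carries 4-cyanobenzyl in place of 4-methoxyphenoxy on an aromatic carbon.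

Going by the values given here, only one measured step bears on this change. It is a 2.1-fold higher number from compound 1 to compound 2 (0.31 log units; beyond the scatter), and it arose when 4-methoxyphenoxy took the place of 3,5-dimethylbenzyl on an aromatic carbon. That step is modest. Compound 3 again has a benzyl group, as compound 1 does with its 2680 nM, but the nitrile on that group has not been tested here, so the earlier step may be only partly reversed. A single step is thin evidence, and the expectation is correspondingly loose. The expected change, in the direction of a lower number, is small: a 1.6-fold lower number from compound 2 to compound 3 (0.20 log units; within the scatter). For compound 3 the estimate is 3500 nM, with an expected range from 1500 nM to 8000 nM.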

Compound 3, half-maximal effective concentration: 7150 nM
For compound 3 the middle estimate is 2.0-fold (0.31 log units) below the measured one, and the stated range covers the measured number.
By their numbers in this assay, from the lowest: compound 1; then compounds 2 and 3 (each within the scatter of the next).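

In this assay, putting 4-cyanobenzyl in place of 4-methoxyphenoxy on this aromatic carbon gives a 1.3-fold higher number from compound 2 to compound 3 (0.11 log units; within the scatter) and so makes no clear difference, which means that a benzyl group here does not by itself bring the number back towards that of compound 1. The comparison of the two benzyl compounds adds something that the first step could not show: 4-cyanophenyl in place of 3,5-dimethylphenyl on a saturated chain carbon bound to an aromatic carbon gives a 2.7-fold higher number from compound 1 to compound 3 (0.43 log units; beyond the scatter) and thus a modest shift, so the groups carried on the outer ring matter here and not only the kind of group attached to the shared core. No measurement shown explains why these numbers differ.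

The compounds shown leave open whether the step between the two benzyl compounds follows from the presence of the nitrile or the absence of the two methyl groups, since both differ at once. An unsubstituted benzyl group, a 4-methylbenzyl group or a 4-chlorobenzyl group would help to separate these two readings.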